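Thiophene alkynes: nitro substitution on the aryl ether

The source may report more compounds than this note shows. Statements on the series, on what has been measured and on what is new or still open speak of the compounds shown alone.

Measured so far:
compound 1, `CC(=O)Nc1ccsc1C#CC(C)(C)O`, 90%
compound 2, `C(#Cc1cccs1)COc1ccccc1`, 63%

In a functional assay on HT-29 cells (Homo sapiens) for inhibition, tested at 100 uM (on this read-out lower numbers stand for less inhibition and higher numbers for more inhibition at the one concentration tested (going by the name of the read-out)), compound 1 gives 90% and compound 2 gives 63%. Compound 2 is the lowest of the two numbers; the nearest value is that of compound 1, which is higher by an amount beyond the usual scatter. Among the compounds with values here, no step between compounds that differ in one place has been measured, so the effect of a single substituent on the shared core is unknown.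

Compound 3, `O=[N+]([O-])c1ccc(OCC#Cc2cccs2)cc1`, differs from compound 2 as follows: nitro in place of hydrogen on an aromatic carbon. The nitro enters on an aromatic carbon of a six-membered aromatic ring of carbon only, para to a group of 9 heavy atoms. The two measured compounds give no basis for a directed step, so the expected step is a number 2 percentage points higher from compound 2 to compound 3 (within the scatter), within the usual scatter. Compound 3 is estimated at 65%, with a range from 40% to 88%.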

Compound 3, a percentage reported as inhibition, at one concentration (the size of the read-out at that concentration, not a potency): 44%
Estimate against measurement, compound 3: 21 percentage points above, within the range that was stated.
By their numbers in this assay, from the lowest: compound 3; then compound 2; then compound 1.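

In this assay, within the data shown here, nitro in place of hydrogen on an aromatic carbon gives a number 19 percentage points lower from compound 2 to compound 3 (beyond the scatter) and this is the only step so far that differs in one place. It shows that the aromatic carbon para to a group of 9 heavy atoms is not silent in this read-out, since a change there alone moves the number beyond the scatter, and that nitro at this place goes with less inhibition at the one concentration tested than hydrogen does. No measured data bear on why the number falls at this position.

As far as these compounds go, with a single step at a single place, it remains open whether an amine or a carboxylic acid on the same aromatic carbon would move the number in the same direction. Also open, from the compounds shown here alone, is whether nitro gives a step of similar size on the other carbons of this ring, or with a longer chain in place of the link between the two rings.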